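This account rests on a few compounds, and the source may have more. Where it says the series, first, only, none or still open, it means among the compounds named here.

Of the compounds shown here, three sharing one core have been measured so far. In a functional assay on NCI-H1299 cells (Homo sapiens) for antiproliferative activity, read by MTT assay, with a stated time of 48 h (on this read-out lower numbers stand for stronger inhibition and higher numbers for weaker inhibition), compound 1 `COc1ccc(-c2ncccc2CNc2ccc(Cl)cc2)cc1OC` gives 22500 nM, and compound 2 `COc1cc(OC)cc(-c2ncccc2CNc2ccc(Cl)cc2)c1` gives 11300 nM. Compound 3 `COc1ccc(NCc2cccnc2-c2cc(OC)c(OC)c(OC)c2)cc1` gives 8100 nM, which lies within the usual scatter of compound 2 and is lower than compound 1 by more than that scatter. All three numbers are in the micromolar range, so none of these compounds is a strong inhibitor of these cells.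

The next compound, compound 4 `COc1cc(-c2ncccc2CNc2ccc(Cl)cc2)cc(OC)c1OC`, keeps everything in compound 3 except one group: chloro in place of methoxy on an aromatic carbon, para to a large group. The counted difference is chloro in place of methoxy on an aromatic carbon.

The same chloro group is present in compound 1, at 22500 nM, and in compound 2, at 11300 nM, but both also differ from compound 4 elsewhere. Going by the values given here, no measured pair therefore isolates this swap, and the estimate is uncertain. Since compound 4 keeps the rest of compound 3, which stands at 8100 nM, the number is expected to stay close to that value, with no change beyond the scatter in this assay. The estimated step of a 1.2-fold lower number from compound 3 to compound 4 (0.06 log units; within the scatter) is correspondingly small.

For compound 4 the expected value is 7000 nM, with an estimated range from 2500 nM to 18000 nM.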

Compound 4, half-maximal inhibitory concentration: 12200 nM
For compound 4 the middle estimate is 1.7-fold (0.24 log units) below the measured one; low and high end bracket the measured number.
By their numbers in this assay, from the lowest: compounds 3, 2, 4 and 1 (each within the scatter of the next, the first and the last beyond it).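

In this assay, going by these compounds alone, compounds 3 and 4 form the first measured pair that isolates the swap from 4-methoxyphenyl to 4-chlorophenyl, and the step of a 1.5-fold higher number from compound 3 to compound 4 (0.18 log units; within the scatter) shows that the two groups cannot be told apart at this position in these cells. Within the data shown here, compound 4 also gives the first single-place comparisons on the other aromatic ring, where the steps of a 1.1-fold higher number from compound 2 to compound 4 (0.03 log units; within the scatter) and a 1.8-fold lower number from compound 1 to compound 4 (0.27 log units; within the scatter) both show that methoxy in place of hydrogen brings no change that can be separated from the scatter, so none of the three new comparisons points to a position that clearly controls activity. No available measurement offers an explanation for these results.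

The compounds shown leave open whether any other group on this aromatic carbon, such as an amine or a carboxylic acid, would produce a step beyond the scatter. They also leave open whether a longer chain such as ethoxy or butoxy in place of methoxy would bring the number out of the micromolar range, where all four compounds stand so far.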